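The compounds below may be only part of what the source reports. "The series", "measured", "known", "first", "only" and "open" are said of these compounds alone.

Measured so far in an assay on liver for inhibition of Fatty-acid amide hydrolase 1 (Rattus norvegicus); on this read-out lower numbers stand for stronger inhibition and higher numbers for weaker inhibition:
- compound 1, `CCCCCCCCCCCCCCCCCC(=O)C(F)(F)F`: 240 nM
- compound 2, `CCCCCCCCCCCCCC(=O)C(F)(F)F`: 490 nM
- compound 3, `CCCCCCCCCC(=O)C(F)(F)F`: 130 nM

Among these three, compound 3 gives the lowest number in this assay; its gap to compound 1 is within the scatter, while its gap to compound 2 is beyond it, so compound 3 cannot be called the strongest outright. The unmeasured compound 4, `CCCCCC(=O)C(F)(F)F`, differs from compound 3 by hydrogen in place of butyl on a saturated chain carbon, five bonds along the chain from a carbonyl carbon.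

Two earlier steps bear on this change, both shortening the saturated chain by a butyl. The first, a 2.0-fold higher number from compound 1 to compound 2 (0.31 log units; beyond the scatter), went toward weaker inhibition; the second, a 3.8-fold lower number from compound 2 to compound 3 (0.58 log units; beyond the scatter), went the other way, toward stronger inhibition. The two steps thus disagree in direction, and neither was large. Within the data shown here, no step of this kind as close to the carbonyl carbon has been measured. Among the measured compounds shown here, a modest change in this assay is expected for compound 4, most likely toward a higher number, since the only step toward stronger inhibition was a 3.8-fold lower number from compound 2 to compound 3 (0.58 log units; beyond the scatter) and the earlier step of a 2.0-fold higher number from compound 1 to compound 2 (0.31 log units; beyond the scatter) went the other way. Compound 4 is therefore estimated at 800 nM, in a range from 150 nM to 4000 nM, which corresponds to an expected step of a 6.2-fold higher number from compound 3 to compound 4 (0.79 log units; beyond the scatter).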

Compound 4, inhibition constant: 26900 nM
Compound 4: middle estimate off by 34-fold (1.53 log units), on the low side; the whole stated range lies below it.
By their numbers in this assay, from the lowest: compounds 3 and 1 (each within the scatter of the next); then compound 2; then compound 4.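

In this assay, removing a butyl at this position is no longer the mild change it was further along the chain: a 210-fold higher number from compound 3 to compound 4 (2.32 log units; beyond the scatter) is a large step, whereas the two earlier steps of this kind were modest and opposite in direction. The size of the change therefore depends on the chain that carries it, and the result at one place does not carry over to another: the same change on two cores in this assay, a 2.0-fold higher number (0.31 log units; beyond the scatter) from compound 1 to compound 2 and a 210-fold higher number (2.32 log units; beyond the scatter) from compound 3 to compound 4, 100-fold (2.01 log units) apart, beyond the scatter of two such steps Among these four compounds, a sharp loss of inhibition appears only with hydrogen in place of butyl five bonds along the chain from a carbonyl carbon, and compound 2 goes against any steady trend among the longer chains.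

The compounds shown leave open where the loss sets in, which a heptyl chain would help to locate. They also leave open whether a carboxylic acid or an amine at the end of the pentyl chain of compound 4 would restore inhibition.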